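Taking the Triflamide off Compound 3

The source may hold more compounds than are shown below. What is called first, only, known or untested is meant among the compounds shown, and "the series" means these compounds.

Of the compounds shown here, three have been measured in an assay for binding affinity to leukotriene B4 receptor 1 (Homo sapiens); a lower number here means a stronger inhibitor, a higher number a weaker inhibitor. Compound 1 `CCCCCCCCCCOc1ccc(CC(O)c2cccc(C(=O)O)c2)nc1CCC(=O)O` gives 429 nM, compound 2 `COc1ccc(CCCCCCOc2ccc(CC(O)c3cccc(C(=O)O)c3)nc2/C=C/C(=O)O)cc1` gives 165 nM, and compound 3 `COc1ccc(CCCCCCCCOc2ccc(CSc3cccc(NS(=O)(=O)C(F)(F)F)c3)nc2/C=C/C(=O)O)cc1` gives 284 nM. Compound 3 thus holds the second highest of the three numbers; its distance to compound 1 and its distance to compound 2 both fall within the scatter of repeated measurements, so no order among the three can be drawn. Compound 4 `COc1ccc(CCCCCCCCOc2ccc(CSc3ccccc3)nc2/C=C/C(=O)O)cc1` has not been measured. It differs from compound 3 in one place: hydrogen in place of ((trifluoromethyl)sulfonyl)amino on an aromatic carbon. For the measured compounds named here, no pair of measured compounds shows this change, so the expectation rests on compound 3 alone. Weaker binding, beyond the scatter, is expected, a step of a 5.3-fold higher number from compound 3 to compound 4 (0.72 log units; beyond the scatter). Compound 4 is therefore estimated at 1500 nM, within a range from 500 nM to 6000 nM.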

Compound 4, inhibition constant: 74 nM
For compound 4 the middle estimate is 20-fold (1.31 log units) above the measured one; the measured number lies below the stated range.
By their numbers in this assay, from the lowest: compound 4; then compounds 2, 3 and 1 (each within the scatter of the next, the first and the last beyond it).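

In this assay, replacing ((trifluoromethyl)sulfonyl)amino on an aromatic carbon with hydrogen gives a 3.8-fold lower number from compound 3 to compound 4 (0.58 log units; beyond the scatter). The ((trifluoromethyl)sulfonyl)amino group is therefore not required for binding in this series, and the unsubstituted ring binds more strongly, a modest step beyond the scatter. Nothing available explains this gain. The compounds shown leave open whether a carboxylic acid or an amine on this aromatic carbon would match hydrogen, and this single pair cannot show whether the step carries over to other cores.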